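The compounds below may be only part of what the source reports. "The series", "measured", "known", "first", "only" and "open" are said of these compounds alone.

Measured compounds:
Compound 1 `FC(F)(F)c1cc(/N=N/Nc2ccc(Cl)c(C(F)(F)F)c2)ccc1Cl` gives 58400 nM in a functional assay on HeLa cells (Homo sapiens) for cytotoxicity, read by MTT assay, with a stated time of 72 h; a lower number here means a stronger inhibitor, a higher number a weaker inhibitor.
Compound 2 `O=C(c1ccccc1F)N(/N=N/c1ccc([N+](=O)[O-])cc1Br)c1ccc([N+](=O)[O-])cc1Br` gives 1200 nM in this assay.

Of these two numbers, compound 2 holds the lower one, and the gap to compound 1 lies well beyond the usual scatter of this assay, so compound 2 stands as the stronger inhibitor of the pair. The two compounds share no single-point difference, so nothing about the size of any one structural change can be read from them directly.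

Compound 3 `CC(=O)OCC(=O)N(/N=N/c1ccc([N+](=O)[O-])cc1Br)c1ccc([N+](=O)[O-])cc1Br` is not yet measured. It keeps the whole of compound 2 apart from one group: acetoxymethyl in place of 2-fluorophenyl on a carbonyl carbon. The aromatic ring that leaves is replaced by a short chain carrying an ester; the rest of the molecule, including both nitro-bearing aryl rings and the triazene linkage, is unchanged.

Going by the values given here, with no measured step of this kind to lean on, the expectation for compound 3 rests on compound 2 alone, whose 1200 nM serves as the anchor. A modest weakening is expected, with the step of a 2.1-fold higher number from compound 2 to compound 3 (0.32 log units; beyond the scatter) estimated to be small and possibly within the scatter. Compound 3 is therefore expected to give about 2500 nM, within a range from 600 nM to 10000 nM.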

Compound 3, half-maximal inhibitory concentration: 490 nM
The estimate for compound 3 lay 5.1-fold (0.71 log units) above the measured number, and the stated range ends above it.
By their numbers in this assay, from the lowest: compound 3; then compound 2; then compound 1.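

Going by these compounds alone, the first measured step at this position shows that the 2-fluorophenyl ring is not needed on this carbonyl carbon for activity in this assay. Putting acetoxymethyl in its place, with no ring and with an ester among its atoms, gives a 2.4-fold lower number from compound 2 to compound 3 (0.39 log units; beyond the scatter) and so a modest gain rather than a loss, with both nitro-bearing aryl rings and the triazene linkage unchanged. This single step shows that the position tolerates a clear change in the kind of group it carries, but the compounds shown offer nothing that explains the gain.

Going by these compounds, whether the lower number goes with the ester of acetoxymethyl or only with the departure of the aromatic ring remains open, and a plain methyl or a hydroxymethyl group on the same carbonyl carbon would separate these two readings. Within the data shown here, how an amine, a carboxylic acid or a longer chain would fare at this position is also open, as is whether the step would keep its size on a core other than the one shared by compound 2 and compound 3.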